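Moving chloro from 2-chlorophenyl to 4-chlorophenyl

This account rests on a few compounds, and the source may have more. Where it says the series, first, only, none or still open, it means among the compounds named here.

In a functional assay on HepG2 cells (Homo sapiens) for cytotoxicity, read by MTT assay, with a stated time of 48 h (on this read-out lower numbers stand for stronger inhibition and higher numbers for weaker inhibition), compound 1 (`Cc1ncc([N+](=O)[O-])n1CCSc1nnc(-c2ccccc2)o1`) gives 17500 nM and compound 2 (`Cc1ncc([N+](=O)[O-])n1CCSc1nnc(-c2ccccc2N)o1`) gives 4500 nM on the shared core. Compound 3 (`Cc1ncc([N+](=O)[O-])n1CCSc1nnc(-c2ccccc2Cl)o1`) reads 15600 nM in this assay, which leaves it level within the scatter with compound 1. It stands apart from the remaining compound, with a 3.5-fold higher number from compound 2 to compound 3 (0.54 log units; beyond the scatter) as the gap.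

The next structure, compound 4 (`Cc1ncc([N+](=O)[O-])n1CCSc1nnc(-c2ccc(Cl)cc2)o1`), has the same atoms as compound 3, joined differently: 4-chlorophenyl in place of 2-chlorophenyl on an aromatic carbon of a five-membered aromatic ring with 2 nitrogen and 1 oxygen (4-chlorophenyl in place of 2-chlorophenyl on an aromatic carbon). Among the compounds with values here, the data hold no measured step that moves a chloro group, so the evidence is indirect. The closest guide is chloro in place of hydrogen, a 1.1-fold lower number from compound 1 to compound 3 (0.05 log units; within the scatter), which stayed small. Within the data shown here, the only modest step from hydrogen, a 3.9-fold lower number from compound 1 to compound 2 (0.59 log units; beyond the scatter), brought in amino, a different group, and offers little guidance here. No change beyond the scatter is therefore expected in this assay, though a modest step in either direction cannot be excluded. The estimated step is a 1.0-fold lower number from compound 3 to compound 4 (0.02 log units; within the scatter), a shift too small to separate the two. Compound 4 is estimated at 15000 nM, with an expected range from 6500 nM to 32000 nM for a measurement.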

Compound 4, half-maximal inhibitory concentration: 7800 nM
Beside the measured number, compound 4's estimate is 1.9-fold (0.28 log units) above it; the measured number falls inside the stated range.
By their numbers in this assay, from the lowest: compounds 2, 4, 3 and 1 (each within the scatter of the next, the first and the last beyond it).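

In this assay, 4-chlorophenyl in place of 2-chlorophenyl gives a 2.0-fold lower number from compound 3 to compound 4 (0.30 log units; within the scatter), so this move on the carbon next to the ring oxygen does not by itself separate the two isomers. Within the data shown here, it does change how chloro in place of hydrogen reads, however: as 4-chlorophenyl, that exchange gives a 2.2-fold lower number from compound 1 to compound 4 (0.35 log units; beyond the scatter), the only chloro step here that clears the scatter, which the 2-chlorophenyl version did not do. Amino is therefore no longer the only substituent to stand apart from compound 1, and 4-chlorophenyl in place of 2-aminophenyl gives a 1.7-fold higher number from compound 2 to compound 4 (0.24 log units; within the scatter), leaving those two level within the scatter.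

The compounds shown offer no measurement that explains why the two chloro isomers relate to compound 1 differently. They also leave open whether a bromo, methoxy or carboxylic acid group in place of the chloro would keep, lose or extend this modest gain, and whether amino would hold its value if moved in the same way as the chloro.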